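One more 3-methylbut-2-en-1-yl group on the shared core

The source may report more compounds than this note shows. Statements on the series, on what has been measured and on what is new or still open speak of the compounds shown alone.

Measured in a functional assay on Hs 683 cells (Homo sapiens) for inhibition, read by MTT assay, with a stated time of 72 h; on this read-out higher numbers stand for weaker inhibition of growth and lower numbers for stronger inhibition of growth:
- compound 1 `CC(C)=CC(=O)NC(=N)NC(=O)C=C(C)C`: 60300 nM
- compound 2 `CC(C)=CCC/C(C)=C/C(=O)NC(=N)NC(=O)C=C(C)C`: 31500 nM

Going by the values given here, compound 2 lies within the scatter of compound 1, the only other compound measured. The next compound, compound 3 `CC(C)=CCC/C(C)=C/C(=O)NC(=N)NC(=O)/C=C(\C)CCC=C(C)C`, differs from compound 2 by 3-methylbut-2-en-1-yl in place of hydrogen on a saturated chain carbon bound to a double-bonded chain carbon. Among the compounds with values here, the same exchange gives the only measured step that bears on this one: a 1.9-fold lower number from compound 1 to compound 2 (0.28 log units; within the scatter). One small step is thin evidence, so a step of similar size and direction in this assay, not clearly beyond the scatter, is expected. The estimated step is a 1.6-fold lower number from compound 2 to compound 3 (0.20 log units; within the scatter). For compound 3 the expected value is 20000 nM, with an estimated range from 8000 nM to 50000 nM.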

Compound 3, concentration for 50% growth inhibition: 32700 nM
Estimate against measurement, compound 3: 1.6-fold (0.21 log units) below; the measured number falls inside the stated range.
By their numbers in this assay, from the lowest: compounds 2, 3 and 1 (each within the scatter of the next).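

In this assay a further 3-methylbut-2-en-1-yl group in place of hydrogen, on a saturated chain carbon bound to a double-bonded chain carbon, gives a 1.0-fold higher number from compound 2 to compound 3 (0.02 log units; within the scatter) and so stays within the scatter. The same exchange has now been read twice on the shared core, and neither step lies beyond the scatter. Adding this group a second time thus leaves the number unchanged within that scatter.

On these data alone, whether an amine, a carboxylic acid or a longer chain at this place would move the number beyond the scatter remains open. Nothing available gives a reason for these small steps.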